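The source may hold more compounds than are shown below. What is called first, only, known or untested is meant among the compounds shown, and "the series" means these compounds.

Working notes on the series. Compound 1 `COc1cc2nc(N3CCN(C(=O)CCCCC4CCSS4)CC3)nc(N)c2cc1OC` and compound 2 `COc1cc2nc(N3CCN(C(=O)CC4CCSS4)CC3)nc(N)c2cc1OC` share one core and differ only in the saturated chain on the carbonyl. In a functional assay on Vas deferens for antagonist activity at Alpha-1A adrenergic receptor (Rattus norvegicus) (on this read-out higher numbers stand for weaker binding and lower numbers for tighter binding), compound 1 gives 64.6 nM and compound 2 gives 1 nM; the step is a 65-fold lower number from compound 1 to compound 2 (1.81 log units; beyond the scatter). For the measured compounds named here, compound 2 therefore stands at the lowest of the two numbers in this assay, with compound 1 as its only neighbour. Compound 3 `COc1cc2nc(N3CCN(C(=O)C4CCSS4)CC3)nc(N)c2cc1OC` is not yet measured; its change from compound 2 is a group of 5 heavy atoms (3 carbon, 2 sulfur; one five-membered non-aromatic ring with 2 hetero atoms) in place of a group of 6 heavy atoms (4 carbon, 2 sulfur; one five-membered non-aromatic ring with 2 hetero atoms), on a carbonyl carbon, so the five-membered ring now sits on the carbonyl carbon whose other neighbour is an amide-type nitrogen in a ring. Going by the values given here, the only measured step that bears on this is a 65-fold lower number from compound 1 to compound 2 (1.81 log units; beyond the scatter), a shortening of the same chain, and it was large. One step is thin ground, and that gain need not continue once the chain is gone. The step expected is a 1.2-fold higher number from compound 2 to compound 3 (0.08 log units; within the scatter), which may well sit within the scatter. The estimate for compound 3 in this assay is 1.2 nM, with a range from 0.2 nM to 7 nM.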

Compound 3, dissociation constant: 18.6 nM
Compound 3: middle estimate off by 16-fold (1.19 log units), on the low side; the measured number lies above the stated range.
By their numbers in this assay, from the lowest: compound 2; then compound 3; then compound 1.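

The gain from shortening the chain does not carry through to the carbonyl carbon: with the group of 5 heavy atoms in place of the group of 6 heavy atoms, the direction reverses in this assay with a 19-fold higher number from compound 2 to compound 3 (1.27 log units; beyond the scatter) as the step. Compound 3 still keeps part of the gain over the longest chain, with a 3.5-fold lower number from compound 1 to compound 3 (0.54 log units; beyond the scatter) as the step, so the lowest number belongs to the intermediate chain of compound 2, and compound 3 goes against any rule that shorter is lower. No measurement shown here accounts for this turn.

Chain lengths between those of compound 2 and compound 1 remain open, so the lowest point is only loosely placed. Also open, as far as these compounds go, is whether the ring sulfurs matter, which a cyclopentyl group on the chain of compound 2 would test.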